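Swapping methoxycarbonyl for tert-butyl in a urea series

The source may report more compounds than this note shows. Statements on the series, on what has been measured and on what is new or still open speak of the compounds shown alone.

In an ADME assay on HepG2 cells (Homo sapiens) for cytotoxicity, with a stated time of 72 h (a higher number here means that more compound is needed for the effect, a lower number that less compound is needed), compound 1 (`CSc1ccc(NC(=O)Nc2cc(C)nc3ccccc23)cc1`) gives 16000 nM and compound 2 (`COC(=O)c1cccc(NC(=O)Nc2cc(C)nc3ccccc23)c1`) gives 23000 nM, two numbers within the scatter of each other. Compound 3 (`Cc1cc(NC(=O)Nc2ccc(N)cc2)c2ccccc2n1`) reads > 25000 nM, which is a limit of the assay and not a number.

Compound 4 (`Cc1cc(NC(=O)Nc2cccc(C(C)(C)C)c2)c2ccccc2n1`) departs from compound 2 by a single change (tert-butyl in place of methoxycarbonyl on an aromatic carbon), tert-butyl in place of methoxycarbonyl on an aromatic carbon. Among the compounds with values here, the only measured step, an at least 1.5-fold higher number from compound 1 to compound 3 (0.19 log units; that floor lies within the scatter), exchanges different groups, so it offers just a weak guide, and no step beyond the scatter is expected here. The estimated step is a 1.4-fold lower number from compound 2 to compound 4 (0.13 log units; within the scatter). In this assay, compound 4 is expected at about 17000 nM, with an estimated range of 7000 nM to 30000 nM.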

Compound 4, half-maximal effective concentration: > 25000 nM
Compound 4 gave a limit, no number (the forecaster's own chance of this, stated with the estimate: 25%); middle value at least 1.4-fold (0.16 log units) from the limit.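

Exchanging methoxycarbonyl for tert-butyl gives an at least 1.0-fold higher number from compound 2 to compound 4 (0.03 log units; that floor lies within the scatter) in this assay. Within the data shown here, the place meta to a large group therefore carries a group with no oxygen and no hydrogen-bond acceptors, and no fall in the number appears, which the earlier compounds did not show. Compound 4 gives a limit and not a number, and such a limit now appears twice in the series: the limit of > 25000 nM in this assay, at which 2 of the 4 values shown sit.

Going by these compounds, how large the step really is stays open. So does whether a carboxylic acid or a longer chain at this place would give a readable number.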